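This account rests on a few compounds, and the source may have more. Where it says the series, first, only, none or still open, it means among the compounds named here.

Measured compounds in an assay on cells with melanin-concentrating hormone receptor 1 (Homo sapiens) as the target, read by radioligand binding; a higher number here means a weaker inhibitor, a lower number a stronger inhibitor:

Compound 1, `Nc1ccc2cccc(OC3CCCCC3)c2n1`: 361 nM
Compound 2, `Nc1ccc2cccc(OCC3CCCC3)c2n1`: 53 nM
Compound 3, `CC#CCCOc1cccc2ccc(N)nc12`: > 2000 nM

The value of compound 3 is a limit of this assay, not a number, as recorded in the limit of > 2000 nM in this assay, at which 1 of the 3 values shown sits. On the numbers shown compound 3 is therefore the weakest of the three: the steps of an at least 5.5-fold higher number from compound 1 to compound 3 (0.74 log units; beyond the scatter) and an at least 37-fold higher number from compound 2 to compound 3 (1.57 log units; beyond the scatter) both run beyond the scatter, so the pent-3-yn-1-yl ether trails both ring-bearing ethers, with compound 2 giving the lowest number of the set.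

Compound 4, `CCCOc1cccc2ccc(N)nc12`, has not been measured in this assay. Its difference from compound 3 is methyl in place of prop-1-yn-1-yl on a saturated chain carbon, two bonds along the chain from an oxygen on an aromatic ring, so the pent-3-yn-1-yl chain of compound 3 becomes a propyl chain. For the measured compounds named here, no measured step changes a chain in this way; the two steps that end at compound 3 show only that a short open chain sits far behind the cyclopentylmethyl and cyclohexyl ethers. A small open chain is therefore expected to stay weak, with the removal of the triple bond leaving any gain uncertain. The expected step of an at least 1.3-fold lower number from compound 3 to compound 4 (0.12 log units; that floor lies within the scatter) is small, near the limit. For compound 4 the estimate in this assay is 1500 nM, within 400 nM to 6000 nM, with a fair chance that only a limit is again reported.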

Compound 4, half-maximal inhibitory concentration: 1100 nM
Compound 4: middle estimate off by 1.4-fold (0.13 log units), on the high side; low and high end bracket the measured number.
By their numbers in this assay, from the lowest: compound 2; then compound 1; then compound 4. At a limit, above all of these: compound 3.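

In this assay, the open-chain ether compound 3 stands only at a limit: the limit of > 2000 nM in this assay, at which 1 of the 4 values shown sits.

A measured number for an open chain on this oxygen now exists, yet an at least 1.8-fold lower number from compound 3 to compound 4 (0.25 log units; that floor lies within the scatter) gives only a floor, so the change from prop-1-yn-1-yl to methyl has no definite size. The propyl ether also trails both ring-bearing ethers beyond the scatter, with a large gap in a 21-fold higher number from compound 2 to compound 4 (1.32 log units; beyond the scatter) and a modest one in a 3.0-fold higher number from compound 1 to compound 4 (0.48 log units; beyond the scatter).

Propyl and pent-3-yn-1-yl are the only open chains here. The compounds shown do not tell the ring and chain length apart in the gap to the ring-bearing ethers. A saturated pentyl chain would separate chain length from the triple bond, and a terminal amine on the propyl chain would test a very different chain end.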